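A few compounds are considered here, and "the series" means these few. Any claim that something is new, unique, unknown or untested is made for them only; others in the source may bear on it.

Measured in a functional assay on MDA-MB-468 cells (Homo sapiens) for inhibition, read by MTT assay; on this read-out higher numbers stand for weaker inhibition of growth and lower numbers for stronger inhibition of growth:
- Compound 1 `CC1=C(/C=C/C(C)=C/C=C/C(C)=C\C(=O)Nc2ccc(O)cc2)C(C)(C)CCC1n1ccnc1`: 6830 nM
- Compound 2 `CC1=C(/C=C/C(C)=C/C=C/C(C)=C\C(=O)NCc2cccc(F)c2)C(C)(C)CCC1n1ccnc1`: 3090 nM
- Compound 3 `CC1=C(/C=C/C(C)=C/C=C/C(C)=C\C(=O)NCc2ccc(O)cc2)C(C)(C)CC=C1c1cncnc1`: 19100 nM

In this assay, compound 2 gives 3090 nM, the lowest number of the three and so the strongest inhibition of growth among them. Compound 1 and compound 3 both have higher numbers, and both gaps lie beyond the usual scatter.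

The next compound, compound 4 `CC1=C(/C=C/C(C)=C/C=C/C(C)=C\C(=O)NCc2ccccc2)C(C)(C)CCC1n1ccnc1`, differs from compound 2 in one place: hydrogen in place of fluoro on an aromatic carbon, turning 3-fluorobenzyl into benzyl (hydrogen in place of fluoro on an aromatic carbon).

For the measured compounds named here, no measured pair isolates this change. The nearest evidence is a 2.2-fold lower number from compound 1 to compound 2 (0.34 log units; beyond the scatter), a modest step that came from replacing 4-hydroxyphenyl with 3-fluorobenzyl on an amide-type nitrogen, a much larger swap than the loss of one fluoro. Compound 3 differs from compound 2 in more than one place, so it offers no clean comparison.

A swap that large moved the number only modestly, so a single fluoro is expected to matter less, with little confidence in the direction. The expected change is a 1.1-fold higher number from compound 2 to compound 4 (0.05 log units; within the scatter), which would not stand out from the scatter. For compound 4, the estimated value is 3500 nM, with an expected range from 1700 nM to 7000 nM.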

Compound 4, concentration for 50% growth inhibition: 7240 nM
The estimate for compound 4 lay 2.1-fold (0.32 log units) below the measured number; the measured number lies above the stated range.
By their numbers in this assay, from the lowest: compound 2; then compounds 1 and 4 (each within the scatter of the next); then compound 3.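

In this assay, the single fluoro on the benzyl ring turns out not to be a minor detail: removing it gives a 2.3-fold higher number from compound 2 to compound 4 (0.37 log units; beyond the scatter), a step of about the same size as a 2.2-fold lower number from compound 1 to compound 2 (0.34 log units; beyond the scatter), even though that earlier swap replaced a whole group. The other new step separates the two parts of that earlier swap, since changing 4-hydroxyphenyl to benzyl gives a 1.1-fold higher number from compound 1 to compound 4 (0.03 log units; within the scatter), so benzyl without the fluoro cannot be told apart from 4-hydroxyphenyl, and among these compounds only the 3-fluorobenzyl group stands out from that level. Nothing available explains why this one atom changes growth inhibition in these cells.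

The compounds shown do not reveal whether the effect is specific to fluoro, a question that chloro, methyl or methoxy on the same aromatic carbon could help answer. From the compounds shown here alone, it also remains open whether fluoro in place of hydrogen would lower the number in the same way on the core of compound 3, which carries a pyrimidine-type ring rather than the imidazole-type ring of compound 2.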